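Chalcone polyamine conjugates: extending the terminal amine

The source may report more compounds than this note shows. Statements on the series, on what has been measured and on what is new or still open speak of the compounds shown alone.

Compound 2 `COc1cc(C(=O)/C=C/c2ccc(OCCCC(=O)NCCCNCCCCN)cc2)cc(OC)c1OC` carries a linear diamine tail on the amide. In a functional assay on PC-3 cells (Homo sapiens) for antiproliferative activity, read by MTT assay, with a stated time of 48 h (a lower number here means a stronger inhibitor, a higher number a weaker inhibitor), compound 2 reaches only the limit of the measurement, > 100000 nM, so no number stands for it. Compound 1 `COc1cc(C(=O)/C=C/c2ccc(OCCCC(=O)NCCCCN(CCCN)CCCCN)cc2)cc(OC)c1OC` gives 55400 nM in this assay, and compound 3 `COc1ccc(/C=C/C(=O)c2cc(OC)c(OC)c(OC)c2)cc1OCCCC(=O)NCCCCN(CCCN)CCCCNCCCN`, with a longer polyamine tail, gives 48100 nM. Among the measured compounds shown here, the one comparable step, an at least 1.8-fold higher number from compound 1 to compound 2 (0.25 log units; that floor lies within the scatter), shows that removing amine-bearing chain weakened the compound, at least to the limit (the limit of > 100000 nM in this assay, at which 1 of the 3 values shown sits).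

Compound 4 `COc1cc(C(=O)/C=C/c2ccc(OCCCC(=O)NCCCNCCCCNCCN)cc2)cc(OC)c1OC` differs from compound 2 by 2-aminoethyl in place of hydrogen on an amine nitrogen, which lengthens the tail in the direction of compound 1 and compound 3. Since the step from compound 1 to compound 2 shrank the tail and raised the number, the reverse kind of change is expected to lower it somewhat, though the floor of that step lies within the scatter. Compound 4 is therefore expected to give about 70000 nM in this assay, between 30000 nM and 150000 nM, an expected step of an at least 1.4-fold lower number from compound 2 to compound 4 (0.15 log units; that floor lies within the scatter).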

Compound 4, half-maximal inhibitory concentration: 34000 nM
The estimate for compound 4 lay 2.1-fold (0.31 log units) above the measured number, and the stated range covers the measured number.
By their numbers in this assay, from the lowest: compounds 4, 3 and 1 (each within the scatter of the next). At a limit, above all of these: compound 2.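

Among the compounds shown here, with 2-aminoethyl in place of hydrogen on an amine nitrogen, an at least 2.9-fold lower number from compound 2 to compound 4 (0.46 log units; beyond the scatter) is the first step in this assay to lie beyond the scatter, so a change at this nitrogen of the tail does register. Compound 2 stands only at a limit, which makes that step a floor: the limit of > 100000 nM in this assay, at which 1 of the 4 values shown sits. A linear tail ending in 2-aminoethyl also matches the branched tail, as a 1.6-fold lower number from compound 1 to compound 4 (0.21 log units; within the scatter) leaves no order between the two compounds.

Still open, going by these compounds, is whether the added amine nitrogen or the added chain carbons carry the step, a question that a 2-hydroxyethyl or a propyl group on this nitrogen would address. Also open, on these data alone, is whether a longer chain here, such as 3-aminopropyl, would move the number further.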